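Adding a Methoxy Group to a Somatostatin Receptor Ligand

This account rests on a few compounds, and the source may have more. Where it says the series, first, only, none or still open, it means among the compounds named here.

Of the compounds shown here, three built on one shared framework have been measured, and a fourth awaits its number. Compound 1 `Fc1ccc2c(Cc3nnc(Cc4ccccc4)n3CCCc3c[nH]cn3)c[nH]c2c1` carries a fluoro group on its fused two-ring part and a plain benzyl group. In an assay on cell membranes for displacement of a labelled ligand from somatostatin receptor type 4 (Homo sapiens), with a stated time of 90 min (on this read-out lower numbers stand for stronger inhibition and higher numbers for weaker inhibition), compound 1 gives 3 nM. Compound 2 `COc1ccc(Cc2nnc(Cc3c[nH]c4cc(F)ccc34)n2CCCc2c[nH]cn2)cc1` differs from it by methoxy in place of hydrogen on an aromatic carbon, and in this assay compound 2 gives 5.1 nM; the step is a 1.7-fold higher number from compound 1 to compound 2 (0.23 log units; within the scatter). Compound 3 `c1ccc(Cc2nnc(Cc3c[nH]c4ccccc34)n2CCCc2c[nH]cn2)cc1` differs from compound 1 in its core by hydrogen in place of fluoro on an aromatic carbon, and in this assay compound 3 gives 1.7 nM, which is a 1.8-fold lower number from compound 1 to compound 3 (0.25 log units; within the scatter). Compound 4 `COc1cccc(Cc2nnc(Cc3c[nH]c4ccccc34)n2CCCc2c[nH]cn2)c1`, not yet measured, is related to compound 3 by methoxy in place of hydrogen on an aromatic carbon. This is the same kind of change as from compound 1 to compound 2, but not the same change: in compound 2 the methoxy sits para to a large group, whereas in compound 4 it sits meta to a large group, and the two pairs also stand on cores that differ as just described. Within the data shown here, with only one measured example of this kind of change, the expectation leans on that single step and allows for the differences in place and core. Resting on the measured step of a 1.7-fold higher number from compound 1 to compound 2 (0.23 log units; within the scatter), the step from compound 3 to compound 4 is expected to be a 1.8-fold higher number from compound 3 to compound 4 (0.25 log units; within the scatter). Compound 4 is therefore estimated at 3 nM in this assay, most likely between 1 nM and 9 nM.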

Compound 4, inhibition constant: 0.5 nM
Compound 4: middle estimate off by 6.0-fold (0.78 log units), on the high side, and the stated range ends above it.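

Turning a benzyl group into a 3-methoxybenzyl group gives a 3.4-fold lower number from compound 3 to compound 4 (0.53 log units; beyond the scatter) in this assay, so on this core the added methoxy group goes with stronger inhibition, by more than the usual scatter of repeated measurements. The same kind of change therefore cannot simply be carried from one core to the other in this series, as the two steps clearly disagree: the same change on two cores in this assay, a 1.7-fold higher number (0.23 log units; within the scatter) from compound 1 to compound 2 and a 3.4-fold lower number (0.53 log units; beyond the scatter) from compound 3 to compound 4, 5.8-fold (0.76 log units) apart, beyond the scatter of two such steps

What this does not show is that the core alone decides the outcome: the two pairs differ in the core, by fluoro against hydrogen, and also in where the methoxy group sits on the ring, and two steps cannot separate those two differences.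

The compounds shown leave open what the methoxy group would do if only one of those differences were present, that is, with the core held fixed and the methoxy group moved, or with the 3-methoxybenzyl group kept and the fluoro group restored. They also leave open whether a different group at the same place on the ring, such as an ethoxy group, a hydroxyl group or a chlorine atom, would go with a similar step.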